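Enlarging the amide substituent in a thiourea-bearing series

This account rests on a few compounds, and the source may have more. Where it says the series, first, only, none or still open, it means among the compounds named here.

Measured compounds:
- compound 1, `O=C(NCc1ccccc1)c1cc(Oc2cccc(NC(=S)Nc3ccc(Cl)cc3)c2)ccn1`, 15800 nM
- compound 2, `CNC(=O)c1cc(Oc2cccc(NC(=S)Nc3ccc(OC(F)(F)F)cc3)c2)ccn1`, 34700 nM
- compound 3, `CC(C)NC(=O)c1cc(Oc2cccc(NC(=S)Nc3ccc(OC(F)(F)F)cc3)c2)ccn1`, 11800 nM

In a functional assay on PC-3 cells (Homo sapiens) for cytotoxicity, read by MTT assay, with a stated time of 48 h (a lower number here means a stronger inhibitor, a higher number a weaker inhibitor), compound 3 gives the lowest number of the three. Compound 1 lies within the scatter of it, so the two cannot be ordered; only compound 2 stands clearly apart. The change to compound 4, `O=C(NCc1ccccc1)c1cc(Oc2cccc(NC(=S)Nc3ccc(OC(F)(F)F)cc3)c2)ccn1`, is benzyl in place of isopropyl on an amide-type nitrogen. Among the measured compounds shown here, one measured step bears on it: a 2.9-fold lower number from compound 2 to compound 3 (0.47 log units; beyond the scatter), which enlarged the same substituent and lowered the number modestly. Compound 1 also carries a benzyl on that nitrogen, though it differs elsewhere, and its value sits close to compound 3. A further small lowering, or none beyond the scatter, is therefore expected for compound 4, a 1.2-fold lower number from compound 3 to compound 4 (0.07 log units; within the scatter). Compound 4 is estimated at 10000 nM, between 4000 nM and 25000 nM.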

Compound 4, half-maximal inhibitory concentration: 6800 nM
Beside the measured number, compound 4's estimate is 1.5-fold (0.17 log units) above it; the range from low to high includes it.
By their numbers in this assay, from the lowest: compounds 4, 3 and 1 (each within the scatter of the next, the first and the last beyond it); then compound 2.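

In this assay, benzyl in place of isopropyl on the amide-type nitrogen gives a 1.7-fold lower number from compound 3 to compound 4 (0.24 log units; within the scatter) and so cannot be told apart from isopropyl, while the larger comparison with the methyl group gives a 5.1-fold lower number from compound 2 to compound 4 (0.71 log units; beyond the scatter) as a clearer gain. This nitrogen therefore accepts a six-membered aromatic ring without losing activity. With benzyl held fixed, trifluoromethoxy in place of chloro gives a 2.3-fold lower number from compound 1 to compound 4 (0.37 log units; beyond the scatter) and shows that the number also answers to a change away from the amide.

No measurement shown explains any of these steps. From the compounds shown here alone, whether a longer chain such as phenethyl, or a chain ending in an amine, would lower the number further remains open.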